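Aryl sulfonyl variation in this series: compound 2 to compound 3

The source may hold more compounds than are shown below. What is called first, only, known or untested is meant among the compounds shown, and "the series" means these compounds.

Compound 1 `COc1ccc(-c2cc(=O)c3c(OC)cc(OC)cc3n2S(=O)(=O)c2ccc(C)c([N+](=O)[O-])c2)cc1` and compound 2 `COc1ccc(-c2cc(=O)c3c(OC)cc(OC)cc3n2S(=O)(=O)c2ccc(F)cc2)cc1` share one core and differ only in the aryl group on the sulfonyl sulfur. In an ADME assay on BJ cells (Homo sapiens) for antiproliferative activity, with a stated time of 72 h (on this read-out higher numbers stand for an effect only at larger amounts of compound and lower numbers for an effect already at smaller amounts), compound 1 reaches only the assay limit > 51700 nM. In this assay compound 2 likewise reaches only the assay limit > 65500 nM. The step that the two limits leave unreadable from compound 1 to compound 2 therefore cannot be read, as the limit of > 51700 nM in this assay, at which 1 of the 2 values shown sits, and the limit of > 65500 nM in this assay, at which 1 of the 2 values shown sits, show. Compound 3 `COc1ccc(-c2cc(=O)c3c(OC)cc(OC)cc3n2S(=O)(=O)c2ccc(C)cc2)cc1` carries methyl in place of fluoro on an aromatic carbon. Among the measured compounds shown here, no measured step bears on this change, so no shift beyond the scatter is expected. Compound 3 is expected to sit at a limit again, estimated at 65500 nM with a range of 30000 nM to 200000 nM. The implied step a number no higher from compound 2 to compound 3 (the limit leaves the size open) is expected to stay within the scatter.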

Compound 3, half-maximal effective concentration: > 44800 nM
Compound 3: a limit, no number; the forecaster's own chance of this, stated with the estimate: 85%; the middle value is on the limit's open side.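

Compound 3 reaches only the limit > 44800 nM in this assay and gives no number. Among the compounds shown here, with compound 1 and compound 2 also at limits, no step among the three can be read. From the compounds shown here alone, whether the aryl group on the sulfonyl sulfur affects this read-out at all stays open.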